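A few compounds are considered here, and "the series" means these few. Any claim that something is new, unique, unknown or untested is made for them only; others in the source may bear on it.

In a functional assay on MDA-MB-435 cells (Homo sapiens) for cytotoxicity, read by MTT assay, with a stated time of 72 h (a lower number here means a stronger inhibitor, a higher number a weaker inhibitor), compound 3 `Nc1ccc(Nc2c(C(=O)NCc3ccc(F)cc3)nc(Br)c3cccnc23)cc1` gives 7000 nM and compound 1 `Nc1cccc(Nc2c(C(=O)NCc3ccc(F)cc3)nc(Br)c3cccnc23)c1` gives 8000 nM, which places these two within the scatter of each other, the gap being a 1.1-fold lower number from compound 1 to compound 3 (0.06 log units; within the scatter). Compound 2 `C[C@@H](Nc1c(C(=O)NCc2ccc(F)cc2)nc(Br)c2cccnc12)c1ccccc1` reads > 20000 nM, a limit and not a number. Compound 4 `O=C(NCc1ccc(F)cc1)c1nc(Br)c2cccnc2c1NCCO` carries this change: 2-hydroxyethyl in place of 4-aminophenyl on a nitrogen on an aromatic ring. In words, 2-hydroxyethyl stands in place of 4-aminophenyl on a nitrogen on an aromatic ring. Leaving an aminophenyl group has been measured only once, as an at least 2.5-fold higher number from compound 1 to compound 2 (0.39 log units; beyond the scatter), so a modest step to a higher number is expected in this assay. The expected change is a 2.3-fold higher number from compound 3 to compound 4 (0.36 log units; beyond the scatter). For compound 4 the estimated value is 16000 nM, with an expected range of 7000 nM to 40000 nM.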

Compound 4, half-maximal inhibitory concentration: > 20000 nM
Compound 4: a limit, no number; the forecaster's own chance of this, stated with the estimate: 40%; middle value at least 1.2-fold (0.09 log units) away from the limit.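

In this assay, 2-hydroxyethyl, which carries no ring, gives an at least 2.8-fold higher number from compound 3 to compound 4 (0.45 log units; beyond the scatter), and an at least 2.5-fold higher number from compound 1 to compound 4 (0.39 log units; beyond the scatter). On this nitrogen on an aromatic ring, a group without a ring therefore also separates from both aminophenyl compounds, which until now only the 1-phenylethyl of compound 2 had done. The step between compound 2 and compound 4 cannot be read, both values being limits and not numbers: the limit of > 20000 nM in this assay, at which 2 of the 4 values shown sit.

From the compounds shown here alone, whether a longer chain ending in an amine or a carboxylic acid would give a number under this limit stays open. The compounds shown also cannot separate the loss of the ring from the entry of the hydroxyl.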